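The source may report more compounds than this note shows. Statements on the series, on what has been measured and on what is new or still open speak of the compounds shown alone.

Compound 1 `CC(=O)N1CCC(C(=O)N(CCCN2CCN(Cc3cnc(Cl)s3)CC2)c2ccc(C)c(Cl)c2)CC1` gives > 52300 nM in an ADME assay (Homo sapiens) for cytotoxicity (a higher number here means that more compound is tolerated, a lower number that less compound is tolerated), a limit of the assay.
Compound 2 `CC(=O)N1CCC(C(=O)N(CCCN2CCN(Cc3ccncc3)CC2)c2ccc(C)c(Cl)c2)CC1` gives > 56700 nM in this assay, also a limit of the assay.
Compound 3 `CC(=O)N1CCC(C(=O)N(CCCN2CCN(Cc3ccccc3)CC2)c2ccc(C)c(Cl)c2)CC1` gives 101000 nM in this assay.

Among the measured compounds shown here, compound 3 therefore holds the only number in this set; the other two values are limits. The step to compound 4 `CC(=O)N1CCC(C(=O)N(CCCN2CCN(Cc3ccc(C(F)(F)F)cc3)CC2)c2ccc(C)c(Cl)c2)CC1` is trifluoromethyl in place of hydrogen on an aromatic carbon. The measured steps a step that the two limits leave unreadable from compound 1 to compound 2, a step that the limit leaves unreadable from compound 1 to compound 3 and a step that the limit leaves unreadable from compound 2 to compound 3 all change the ring on the saturated chain carbon bound to an amine nitrogen in a ring, yet none gives a readable size because of the limit of > 52300 nM in this assay, at which 1 of the 3 values shown sits, and (the limit of > 56700 nM in this assay, at which 1 of the 3 values shown sits). For the measured compounds named here, with no measured step setting a size, compound 4 is expected to stay close to compound 3, a step of a 1.3-fold lower number from compound 3 to compound 4 (0.10 log units; within the scatter) that lies within the scatter. Compound 4 is estimated at 80000 nM, between 30000 nM and 200000 nM.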

Compound 4, half-maximal cytotoxic concentration: 30500 nM
Estimate against measurement, compound 4: 2.6-fold (0.42 log units) above, within the range that was stated.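

In this assay, among the compounds shown here, the change on the aromatic carbon para to a large group gives the first step of readable size in this set (a 3.3-fold lower number from compound 3 to compound 4 (0.52 log units; beyond the scatter)), so this position does respond to trifluoromethyl in place of hydrogen. Compounds 1 and 2 stand at limits of the assay, and the steps from them are floors only (an at least 1.8-fold lower number from compound 2 to compound 4 (0.26 log units; that floor lies within the scatter)) and (an at least 1.7-fold lower number from compound 1 to compound 4 (0.23 log units; that floor lies within the scatter)). No measured property shown here accounts for the drop.

On these data alone, whether a methoxy group, a chlorine or a nitrile at the same place would lower the number too stays open.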